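This account rests on a few compounds, and the source may have more. Where it says the series, first, only, none or still open, it means among the compounds named here.

The study concerns a small set of compounds that share a core and are examined in an ADME assay on L02 cells (Homo sapiens) for inhibition, read by MTT assay, with a stated time of 48 h, tested at 100 uM; on this read-out higher numbers stand for more inhibition at the one concentration tested (going by the name of the read-out) and lower numbers for less inhibition. Compound 1, with structure `O=c1nc(-c2cc(F)c(Cl)nc2Cl)ss1`, gives 24.3% in this assay. Compound 2, with structure `Nc1ccc(-c2nsc(=O)o2)cc1`, gives 39.5% in this assay. Compound 3, with structure `COc1ccc(OC)c(-c2nsc(=O)o2)c1`, gives 25.3% in this assay. On these three numbers compound 3 stands second highest: its nearest neighbour is compound 1, whose value lies within the scatter of it, so no order between those two can be drawn, while its furthest neighbour is compound 2, whose value lies beyond the scatter and above it.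

The account now follows the step from compound 3 to compound 4, whose structure is `COc1cccc(-c2nsc(=O)o2)c1`. The change between them is hydrogen in place of methoxy on an aromatic carbon. Among the measured compounds shown here, no step between two measured compounds of this kind is available, so the expectation rests on compound 3 alone. Since compound 3 gives 25.3% in this assay, a step of a number 1.3 percentage points lower from compound 3 to compound 4 (within the scatter) is expected, that is, none beyond the scatter in either direction. Compound 4 is therefore estimated to give 24% in this assay, with a range from 12% to 38%.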

Compound 4, a percentage reported as inhibition, at one concentration (the size of the read-out at that concentration, not a potency): 15%
Compound 4: middle estimate off by 9 percentage points, on the high side; measured number inside the range.
By their numbers in this assay, from the lowest: compounds 4, 1 and 3 (each within the scatter of the next, the first and the last beyond it); then compound 2.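

Among the compounds shown here, replacing methoxy with hydrogen on this aromatic carbon, ortho to a group of 6 heavy atoms and para to a methoxy group, gives a step of a number 10.3 percentage points lower from compound 3 to compound 4 (beyond the scatter) in this assay, and this is the first pair in the set that differs in one place. The position is therefore not indifferent on this read-out: in this single pair, the compound that keeps the methoxy group shows more inhibition at the one concentration tested than the compound carrying hydrogen, although one modest step cannot establish a general trend. No measurement offered here accounts for the size or direction of this step.

The compounds shown leave open whether the step belongs to methoxy in particular or whether a fluorine, an amine or a longer chain such as ethoxy on this same carbon would give a similar number. For the compounds shown here, they also leave open what the methoxy group that remains in compound 4 contributes, as they include no pair in which that group alone is changed.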